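Toward compound 4 in a series held at the limit

The source may hold more compounds than are shown below. What is called first, only, known or untested is meant among the compounds shown, and "the series" means these compounds.

Values in a functional assay on L5178Y cells (Mus musculus) for inhibition, read by MTT assay, with a stated time of 24 h; a higher number here means a weaker inhibitor, a lower number a stronger inhibitor:
- compound 1 `Cn1cccc1/C=N/N=C1\C[C@@H](c2ccc(O)cc2)Oc2cc(O)cc(O)c21`: >= 11300 nM
- compound 2 `Oc1ccc([C@@H]2C/C(=N\N=C\c3c[nH]c4ccccc34)c3c(O)cc(O)cc3O2)cc1`: >= 11300 nM
- compound 3 `O=C(Cc1c[nH]c2ccccc12)N/N=C1\C[C@@H](c2ccc(O)cc2)Oc2cc(O)cc(O)c21`: >= 11300 nM

Each of these values is a limit and not a number. Going by the values given here, compound 1 therefore has no exact standing, and the series so far shows only (the limit of >= 11300 nM in this assay, at which 3 of the 3 values shown sit). Compound 4 `CN(C)C(=S)N/N=C1\C[C@@H](c2ccc(O)cc2)Oc2cc(O)cc(O)c21` carries a change on a double-bonded nitrogen: a group of 6 heavy atoms (3 carbon, 2 nitrogen, 1 sulfur; no ring) in place of a group of 8 heavy atoms (6 carbon, 2 nitrogen; one five-membered aromatic ring with 1 hetero atom), on a double-bonded nitrogen. Among the compounds with values here, the one measured step is a step that the two limits leave unreadable from compound 1 to compound 2, and it gives no size to carry over. The group entering compound 4 has no ring, unlike the groups in that step. No direction or size for this change in this assay can be drawn from the data, so a result near the same limit is expected. The estimated step is an at least 1.1-fold lower number from compound 1 to compound 4 (0.05 log units; that floor lies within the scatter). Compound 4 is estimated at 10000 nM, with an expected range from 3000 nM to 20000 nM.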

Compound 4, half-maximal inhibitory concentration: >= 11300 nM
Compound 4: no number, only a limit; the forecaster's own chance of this, stated with the estimate: 60%; at least 1.1-fold (0.05 log units) between middle value and limit.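

In this assay compound 4 gives >= 11300 nM, a limit and not a number, so the step from compound 1 to compound 4 cannot be read. The compounds shown leave open whether any group on the double-bonded nitrogen can bring a measurable value in this assay, and the series stays where it was: the limit of >= 11300 nM in this assay, at which 4 of the 4 values shown sit.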